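The source may report more compounds than this note shows. Statements on the series, on what has been measured and on what is new or still open speak of the compounds shown alone.

Working notes on the series in an ADME assay on DU-145 cells (Homo sapiens) for cytotoxicity, read by MTT assay, with a stated time of 72 h; a lower number here means a stronger inhibitor, a higher number a weaker inhibitor. Compound 3 (`COc1cc(C2=C(c3ccccc3)C(O[SiH2]C(C)(C)C)CC2=O)cc(OC)c1OC`) gives > 100 ug/mL here, which is a limit and not a number. Compound 1 (`COc1cc(C2=C(c3cc(C)c(OC)c(C)c3)C(O)CC2=O)cc(OC)c1OC`) gives > 100 ug/mL here, also a limit. Compound 2 (`COc1cc(C2=C(c3cc(C)c(OC)c(C)c3)C(OC(C)=O)CC2=O)cc(OC)c1OC`) gives > 100 ug/mL here, again a limit. Compound 4 (`COc1cc(C2=C(c3cc(C)c(OC)c(C)c3)C(O[SiH2]C(C)(C)C)CC2=O)cc(OC)c1OC`) differs from compound 3 as follows: 4-methoxy-3,5-dimethylphenyl in place of phenyl on a double-bonded ring carbon. In words, 4-methoxy-3,5-dimethylphenyl stands in place of phenyl on a double-bonded ring carbon, the group that compound 1 and compound 2 already carry. Within the data shown here, the one measured step is a step that the two limits leave unreadable from compound 1 to compound 2 and it has no readable size, so it gives no magnitude to carry over. No step beyond the scatter is expected in this assay because of the limit of > 100 ug/mL in this assay, at which 3 of the 3 values shown sit, and this covers compound 1, compound 2 and compound 3 alike. The expected change is a step that the limit leaves unreadable from compound 3 to compound 4 and no direction is favoured. For compound 4 the estimated value is 150 ug/mL with an expected range of 80 ug/mL to 300 ug/mL and a report as a limit is the likeliest outcome.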

Compound 4, half-maximal inhibitory concentration: > 100 ug/mL
Compound 4: no number, only a limit (the forecaster's own chance of this, stated with the estimate: 85%); the middle value does not contradict the limit.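

In this assay compound 4 gives > 100 ug/mL, a limit and not a number. No step from compound 1, compound 2 or compound 3 to compound 4 can therefore be read: the limit of > 100 ug/mL in this assay, at which 4 of the 4 values shown sit.

The compounds shown leave open which change to the shared core, if any, would give a readable number.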